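The compounds below may be only part of what the source reports. "The series", "measured", "known", "first", "only" and "open" are said of these compounds alone.

Measured compounds:
compound 1 `ClCc1ccccc1Cn1cnc2c(Cl)nc(Cl)nc21`, 2400 nM
compound 2 `ClCc1ccccc1Cn1cnc2c(Cl)ncnc21`, 17400 nM
compound 3 `ClCc1ccc(Cn2cnc3c(Cl)nc(Cl)nc32)cc1`, 12000 nM

All three were tested in a functional assay on A498 cells (Homo sapiens) for cytotoxicity, read by sulforhodamine B assay, with a stated time of 48 h; a lower number here means a stronger inhibitor of growth, a higher number a weaker inhibitor of growth. Compound 2 gives the highest number of the three, that is, it is the weakest inhibitor of growth among them in this assay. Compound 3 lies close to it, and the gap between these two is within the usual scatter, so nothing separates them. Compound 1 stands clearly apart: a 7.3-fold higher number from compound 1 to compound 2 (0.86 log units; beyond the scatter), so taking that chloro away weakened the effect by a clear margin.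

Compound 4 `Nc1nc(Cl)c2ncn(Cc3ccccc3CCl)c2n1` has not yet been measured. It differs from compound 2 in one place: amino in place of hydrogen on an aromatic carbon. The amino therefore enters exactly the position that carries chloro in compound 1 and hydrogen in compound 2. Among the measured compounds shown here, the only measured step that touches this position is the one from compound 1 to compound 2, and it shows that the position matters for the result. Putting a substituent back there is therefore expected to lower the number again, though an amino is not a chloro, so the size of the gain is uncertain and is expected to fall short of a full return to compound 1. The expected step is a 2.9-fold lower number from compound 2 to compound 4 (0.46 log units; beyond the scatter). For compound 4 the estimate is 6000 nM, with a range from 1500 nM to 20000 nM.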

Compound 4, concentration for 50% growth inhibition: 20400 nM
Compound 4: the middle estimate sits 3.4-fold (0.53 log units) below what was measured; measured number outside the range, above it.
By their numbers in this assay, from the lowest: compound 1; then compounds 3, 2 and 4 (each within the scatter of the next).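

In this assay, an amino on this aromatic carbon between two ring nitrogen atoms does not act like the chloro of compound 1: there is a 1.2-fold higher number from compound 2 to compound 4 (0.07 log units; within the scatter) and so compound 4 cannot be told apart from compound 2 in this test. Measured directly against the chloro, the exchange gives an 8.5-fold higher number from compound 1 to compound 4 (0.93 log units; beyond the scatter) and this places amino with hydrogen, clearly separate from chloro. The earlier step showed only that losing chloro mattered, whereas this result shows that simply having a substituent at the position is not enough, since among hydrogen, amino and chloro only chloro goes with the lower number, and no supporting data are available to explain this.

Among the compounds shown here, with only three groups seen at this position, it remains open whether a bromo, a fluoro, a methyl or a methoxy would follow chloro or fall with hydrogen and amino. On these data alone, it also remains open whether a larger amine, such as a dimethylamino group, would match the simple amino, and whether the same order of groups would hold with the chloromethyl placed as in compound 3.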